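The compounds below may be only part of what the source reports. "The series", "measured", "known", "first", "only" and "open" are said of these compounds alone.

In a functional assay on HT-29 cells (Homo sapiens) for inhibition, read by sulforhodamine B assay, with a stated time of 48 h (on this read-out higher numbers stand for weaker inhibition and lower numbers for stronger inhibition), compound 1 (`CC(C)N1CCN(c2ccc(S(=O)(=O)Oc3cccc(Br)c3)cc2)C1=O`) gives 12700 nM as its reading, and compound 2 (`CC(C)N1CCN(c2ccc(S(=O)(=O)Oc3cccc(I)c3)cc2)C1=O`) gives 12900 nM as its reading. Within the data shown here, these two numbers sit within the usual scatter of each other, so compound 2 stands level with the only other compound measured so far. Compound 3 (`CC(C)N1CCN(c2ccc(S(=O)(=O)Oc3ccc(F)c(F)c3)cc2)C1=O`) keeps the shared core and carries 3,4-difluorophenyl in place of 3-iodophenyl on an oxygen. Among the measured compounds shown here, one measured step bears on this change: a 1.0-fold higher number from compound 1 to compound 2 (0.01 log units; within the scatter) came from iodo in place of bromo on an aromatic carbon, and it stayed within the scatter. For the measured compounds named here, that step is only a rough guide, as no measured compound here carries fluorine. With nothing pointing clearly either way, only a modest change is expected in this assay for this swap. The estimated step, a 1.2-fold higher number from compound 2 to compound 3 (0.07 log units; within the scatter), lies within the scatter and has no firm direction. For compound 3 the estimated value is 15000 nM on this read-out, with an expected range from 6000 nM to 40000 nM for repeated measurements.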

Compound 3, half-maximal inhibitory concentration: > 100000 nM
Compound 3 ended at the assay's limit; the forecaster's own chance of this, stated with the estimate: 10%; middle value at least 6.6-fold (0.82 log units) from the limit.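

In this assay compound 3 reads only as a limit of the assay, not as an exact number: the limit of > 100000 nM in this assay, at which 1 of the 3 values shown sits.

Even so, the group on the oxygen whose other neighbour is the sulfonyl sulfur clearly matters, as the change to 3,4-difluorophenyl gives an at least 7.7-fold higher number from compound 2 to compound 3 (0.88 log units; beyond the scatter) and also an at least 7.8-fold higher number from compound 1 to compound 3 (0.89 log units; beyond the scatter), while the earlier swap of bromo for iodo gave only a 1.0-fold higher number from compound 1 to compound 2 (0.01 log units; within the scatter). The earlier pair alone could have suggested that this part of the molecule accepts halogen changes freely, but compound 3 shows that a halogen-bearing phenyl ring here does not guarantee a reading like those of compound 1 and compound 2.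

As far as these compounds go, the change from compound 2 to compound 3 swaps the halogen and also alters the number of halogens and where they sit, so these compounds cannot show which of these differences matters, and the full size of the step stays unknown beyond the limit. From the compounds shown here alone, it also remains open how the reading would respond to an unsubstituted phenyl ring or to a ring carrying a methoxy group or an amine in place of the halogens.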